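The source may report more compounds than this note shows. Statements on the series, on what has been measured and on what is new or still open speak of the compounds shown alone.

Series notes. Compound 1 `CCCCCCCCCCNC(=O)C1C(C(=O)O)[C@@H]2CC[C@H]1O2`, compound 2 `CCc1ccccc1NC(=O)C1C(C(=O)O)[C@@H]2CC[C@H]1O2` and compound 3 `CCOC(=O)c1cn[nH]c1NC(=O)C1C(C(=O)O)[C@@H]2CC[C@H]1O2` share one core and were run in an ADME assay on A-431 cells (Homo sapiens) for cytotoxicity, read by MTT assay, with a stated time of 72 h; on this read-out lower numbers stand for stronger inhibition of growth and higher numbers for weaker inhibition of growth. In this assay compound 1 gives 10000 nM, compound 2 gives 10000 nM and compound 3 gives 10000 nM. Compound 2 stands level with compounds 1 and 3 at the digits recorded, within the scatter of the read-out, so no order among the three can be drawn. Compound 4 `O=C(O)C1C(C(=O)Nc2ccccc2)[C@H]2CC[C@@H]1O2` is the next entry. Relative to compound 2 the change is hydrogen in place of ethyl on an aromatic carbon, on an aromatic carbon of a six-membered aromatic ring of carbon only. Within the data shown here, no step between measured pairs is available, so the step in this assay from compound 2 to compound 4 is expected to be none beyond the scatter. The expected step is no change at the digits printed from compound 2 to compound 4 (within the scatter). Compound 4 is expected to give 10000 nM in this assay, between 5000 nM and 20000 nM.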

Compound 4, concentration for 50% growth inhibition: 10000 nM
Beside the measured number, compound 4's estimate shows no gap at the digits printed; low and high end bracket the measured number.
By their numbers in this assay, from the lowest: compounds 1, 2, 3 and 4 (each within the scatter of the next).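

Hydrogen in place of ethyl on an aromatic carbon, ortho to a large group, gives no change at the digits printed from compound 2 to compound 4 (within the scatter) in this read-out (this assay). Among these compounds, this is the first comparison that differs in one place, and at this position ethyl and hydrogen read alike. No supporting measurement bears on this result.

On these data alone, whether an amine, a carboxylic acid or a longer chain on this aromatic carbon would shift the value remains open. As far as these compounds go, the effect of either group on a compound with a lower value also remains open.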